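This account rests on a few compounds, and the source may have more. Where it says the series, first, only, none or still open, it means among the compounds named here.

Compound 1 `Nc1nc(Cl)c2ncn(Cc3ccccc3CCl)c2n1` is tested for cell killing in a functional assay on SW-620 cells (Homo sapiens) for cytotoxicity, read by sulforhodamine B assay, with a stated time of 48 h; on this read-out higher numbers stand for lower toxicity in this test and lower numbers for higher toxicity in this test. Here compound 1 gives only a limit, > 100000 nM, so its true toxicity is not pinned to a number; it sits at the limit of > 100000 nM in this assay, at which 1 of the 2 values shown sits. A second compound, compound 2 `ClCc1ccccc1Cn1cnc2ncnc(Cl)c21`, is measured in this assay as well, and compound 2 gives 10000 nM. The untested compound 3 `ClCc1ccccc1Cn1cnc2c(Cl)ncnc21` differs from compound 1 by a single change: hydrogen in place of amino on an aromatic carbon. Within the data shown here, no measured pair shows this change, so the expected step from compound 1 to compound 3 in this assay, an at least 3.3-fold lower number from compound 1 to compound 3 (0.52 log units; beyond the scatter), is a guess toward somewhat higher toxicity. Compound 3 is therefore estimated at 30000 nM, within 8000 nM to 100000 nM.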

Compound 3, concentration lethal to 50% of the cells: 26300 nM
Compound 3: middle estimate off by 1.1-fold (0.06 log units), on the high side; low and high end bracket the measured number.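

Hydrogen in place of amino on the aromatic carbon between two ring nitrogen atoms gives an at least 3.8-fold lower number from compound 1 to compound 3 (0.58 log units; beyond the scatter) in this assay and thus provides the first measured step at this position. On this core, losing the amino group goes with higher toxicity in this test. The full size of the step stays unknown because compound 1 stands at a limit: the limit of > 100000 nM in this assay, at which 1 of the 3 values shown sits.

On these data alone, whether the amino group is special here remains open. A methyl or a methoxy group on the same carbon could show whether other groups also give a high number in this test.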